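Phenyl for Methyl on Sulfur across Two Related Cores

The source may hold more compounds than are shown below. What is called first, only, known or untested is meant among the compounds shown, and "the series" means these compounds.

Measured so far:
compound 1, `CCN(CC)CCNC(=O)c1ccc(C(CC)(CC)c2ccc(OCSC)c(C)c2)n1CC`: 74.6 ug/mL
compound 2, `CCN(CC)CCNC(=O)c1ccc(C(CC)(CC)c2ccc(OCSc3ccccc3)c(C)c2)n1CC`: 25.6 ug/mL
compound 3, `CCN(CC)CCNC(=O)c1cc(C(CC)(CC)c2ccc(OCSC)c(C)c2)cn1CC`: 198 ug/mL

Of the compounds shown here, three have been tested in a physicochemical assay for solubility, read by HPLC, at pH 7.4; on this read-out lower numbers stand for lower solubility and higher numbers for higher solubility. Compound 1 and compound 2 share a core and differ by phenyl in place of methyl on a sulfur; the step was a 2.9-fold lower number from compound 1 to compound 2 (0.46 log units; beyond the scatter). Compound 3 carries the same atoms as compound 1 joined differently, and the difference between the two cores is not broken down here. In this assay compound 3 gives 198 ug/mL, the highest of the three numbers, while compound 1 gives 74.6 ug/mL and compound 2 gives 25.6 ug/mL.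

Compound 4, `CCN(CC)CCNC(=O)c1cc(C(CC)(CC)c2ccc(OCSc3ccccc3)c(C)c2)cn1CC`, has not yet been measured. It differs from compound 3 by phenyl in place of methyl on a sulfur. The place of the change reads the same, word for word, as the place of the change from compound 1 to compound 2, so this is the same change made on the core of compound 3.

In this assay compound 4 is therefore expected to sit below compound 3 by a step of a 2.9-fold lower number from compound 3 to compound 4 (0.46 log units; beyond the scatter). Going by the values given here, that expectation rests on the one measured instance of this change, a 2.9-fold lower number from compound 1 to compound 2 (0.46 log units; beyond the scatter), with the caveat that a single pair carries the whole weight and the two cores are not the same. Compound 4 is estimated to give 68 ug/mL, most likely between 35 ug/mL and 130 ug/mL.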

Compound 4, solubility: 0.6 ug/mL
Beside the measured number, compound 4's estimate is 110-fold (2.05 log units) above it, and the stated range ends above it.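

On the core of compound 3, phenyl in place of methyl on a sulfur again gives a lower number in this assay, with a 330-fold lower number from compound 3 to compound 4 (2.52 log units; beyond the scatter) against a 2.9-fold lower number from compound 1 to compound 2 (0.46 log units; beyond the scatter) on the core of compound 1, so the direction of the change carried over from one core to the other while its size did not. Both steps lie beyond the scatter, and the second is far larger, which means the step measured on one of these cores could not be used as a measure of the step on the other. With a single pair on each core, this shows only that the size of the change differed between these two cores, and it does not show how the same change would behave on any further core or what sets the size of the step, as nothing available bears on why the two steps differ.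

The compounds shown carry only methyl and phenyl on the sulfur, so it remains open how an ethyl, a benzyl or a pyridyl group in that place would read on either core. From the compounds shown here alone, it is also open whether a cyclohexyl group there would bring a step as large as the one from phenyl on the core of compound 3.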